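A few compounds are considered here, and "the series" means these few. Any claim that something is new, unique, unknown or untested is made for them only; others in the source may bear on it.

Working notes on the series. Among the compounds with values here, in an assay on cells for displacement of a labelled ligand from D(4) dopamine receptor (Homo sapiens) (on this read-out higher numbers stand for weaker inhibition and lower numbers for stronger inhibition), compound 2 `COc1cc2c(cc1O)CN(CCCCNC(=O)c1ccc(-c3ccccc3)cc1)CC2` gives 720 nM, which stands second highest of the three numbers measured so far. Compound 1 `COc1cc2c(cc1O)CN(CCCCNC(=O)c1ccnc3ccccc13)CC2` gives 410 nM in this assay, and compound 3 `COc1cc2c(cc1O)CN(CCCCNC(=O)c1ccncc1)CC2` gives 1400 nM; the gaps from compound 2 to either of them lie within the scatter, so no order among the three can be read from these values. Within the data shown here, the only step between measured compounds that differ in one place is a 3.4-fold higher number from compound 1 to compound 3 (0.53 log units; beyond the scatter), with pyridin-4-yl in place of quinolin-4-yl on a carbonyl carbon, a loss of ring area on the amide side of the shared core.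

Compound 4 `COc1cc2c(cc1O)CN(CCCCNC(=O)c1ccc(F)cc1)CC2` is not yet measured. It differs from compound 2 by fluoro in place of phenyl on an aromatic carbon, again a reduction of the aromatic portion on the amide side. Among the measured compounds shown here, no measured step covers this exact change; the one step that bears on it is the shrinkage from compound 1 to compound 3, which gave a modest increase beyond the scatter. A step of comparable size is therefore expected, a 2.1-fold higher number from compound 2 to compound 4 (0.32 log units; beyond the scatter), towards a higher number. Compound 4 is estimated at 1500 nM in this assay, with a range from 500 nM to 4500 nM.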

Compound 4, inhibition constant: 95 nM
Beside the measured number, compound 4's estimate is 16-fold (1.20 log units) above it, outside the stated range (below it).
By their numbers in this assay, from the lowest: compound 4; then compounds 1, 2 and 3 (each within the scatter of the next, the first and the last beyond it).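

In this assay, within the data shown here, the shrinkage at this position runs opposite to the one earlier step: fluoro in place of phenyl, on an aromatic carbon para to a large group, gives a 7.6-fold lower number from compound 2 to compound 4 (0.88 log units; beyond the scatter) here, whereas the earlier loss of ring area raised the number. Less aromatic area on the amide side therefore does not by itself mean a higher number, and the 4-fluorophenyl amide also stands apart from the two heteroaromatic amides, with a 15-fold lower number from compound 3 to compound 4 (1.17 log units; beyond the scatter) and with a 4.3-fold lower number from compound 1 to compound 4 (0.64 log units; beyond the scatter) as well. Nothing measured on these compounds offers a cause for this reversal.

On these data alone, whether the drop belongs to fluoro itself or to any small group stays open; chloro, methoxy or plain hydrogen at this place would separate the two. As far as these compounds go, how a longer chain between the core and the 4-fluorophenyl amide would read also remains open.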